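The compounds below may be only part of what the source reports. "The series", "measured", "known", "first", "only" and "open" are said of these compounds alone.

In a functional assay on cells (CNS carcinoma cell, Homo sapiens) for cytotoxicity, read by sulforhodamine B assay, with a stated time of 48 h (on this read-out lower numbers stand for higher toxicity in this test and higher numbers for lower toxicity in this test), compound 1 `COc1cc2c(cc1C)NC(=O)/C2=C/c1c(OC)nc2sc(C)cn12` gives 68300 nM and compound 2 `COc1ccc2c(c1)/C(=C\c1c(OC)nc3sc(C)cn13)C(=O)N2` gives 85400 nM, so compound 2 stands level with compound 1 within the usual scatter of repeated measurements. Compound 3 `COc1nc2sc(C)cn2c1/C=C1/C(=O)Nc2ccccc21` has not yet been measured. It differs from compound 2 by one change, (hydrogen in place of methoxy on an aromatic carbon), which puts hydrogen in place of methoxy on an aromatic carbon. For the measured compounds named here, only one measured step bears on this, a 1.3-fold higher number from compound 1 to compound 2 (0.10 log units; within the scatter), in which hydrogen takes the place of methyl on an aromatic carbon. That step involves a different group, so it offers only a loose guide, but removing a small group there left the number within the scatter. No change beyond the scatter is therefore expected, and the expected step is a 1.1-fold lower number from compound 2 to compound 3 (0.03 log units; within the scatter). For compound 3 the estimated value is 80000 nM, with an expected range from 35000 nM to 170000 nM.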

Compound 3, concentration lethal to 50% of the cells: 87900 nM
The estimate for compound 3 lay 1.1-fold (0.04 log units) below the measured number; the range from low to high includes it.
By their numbers in this assay, from the lowest: compounds 1, 2 and 3 (each within the scatter of the next).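

In this assay, putting hydrogen in place of methoxy on this aromatic carbon gives a 1.0-fold higher number from compound 2 to compound 3 (0.01 log units; within the scatter), so compound 2 and compound 3 stand level. The earlier step concerned only a methyl group, whereas this one shows that the methoxy group, with its oxygen and its one hydrogen-bond acceptor, can leave this carbon of the six-membered ring with the number staying within the scatter. Nothing measured here gives a reason for this result.

The compounds shown leave open whether a group of another kind on this carbon, such as an amine, a carboxylic acid or a longer chain like butoxy, would move the number beyond the scatter. For the compounds shown here, since hydrogen and methoxy are the only two groups compared here, they say little about how other groups would behave at this position.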